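The compounds below may be only part of what the source reports. "The series", "measured", "known", "first", "only" and "open" are said of these compounds alone.

A small set of acetylated cysteine derivatives was examined in a functional assay on GC3/C1 cells (Homo sapiens) for cytotoxicity, read by MTT assay, with a stated time of 6 days; on this read-out lower numbers stand for stronger inhibition and higher numbers for weaker inhibition. Compound 1 (`CC(=O)N[C@@H](CSC(=O)Nc1ccccc1F)C(=O)O`) gives > 200000 nM, which is a limit of the assay and not a number. Compound 2 (`COc1ccc(NC(=O)SC[C@H](NC(C)=O)C(=O)O)cc1`) gives > 200000 nM, which is also a limit. Compound 1 therefore stands at the limit of > 200000 nM in this assay, at which 2 of the 3 values shown sit. Only compound 3 (`CC(=O)N[C@@H](CSC(=O)Nc1ccc(Br)cc1)C(=O)O`) has a measured number, 63500 nM.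

Compound 4 (`CC(=O)N[C@@H](CSC(=O)Nc1ccccc1)C(=O)O`) comes from compound 1 through one change, hydrogen in place of fluoro on an aromatic carbon, ortho to a large group. For the measured compounds named here, no measured step removes a fluoro, so the evidence for this change is indirect. The nearest step is an at least 3.1-fold lower number from compound 2 to compound 3 (0.49 log units; beyond the scatter), which lies beyond the scatter. It exchanges methoxy for bromo, however, and it starts from a limit, so it gives only a loose guide to size. It shows that one substituent exchange on this ring can bring a number into range in this assay, but it does not show that losing fluoro would do so.

No step beyond the scatter is therefore expected in either direction, and a further limit is the likeliest report. The estimated step is a number no higher from compound 1 to compound 4 (the limit leaves the size open). The estimate for compound 4 is 200000 nM, with an expected range from 90000 nM to 400000 nM.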

Compound 4, half-maximal inhibitory concentration: 178000 nM
Compound 4: the middle estimate sits 1.1-fold (0.05 log units) above what was measured; the range from low to high includes it.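

With compound 4, the set in this assay gains a reference whose ring carries no substituent, and hydrogen in place of bromo gives a 2.8-fold higher number from compound 3 to compound 4 (0.45 log units; beyond the scatter). This ties the lower number of compound 3 to the bromo rather than to the shared core alone, although the step is modest and rests on a single pair. Hydrogen in place of fluoro gives an at least 1.1-fold lower number from compound 1 to compound 4 (0.05 log units; that floor lies within the scatter), and hydrogen in place of methoxy gives an at least 1.1-fold lower number from compound 2 to compound 4 (0.05 log units; that floor lies within the scatter). Neither of these two steps can be sized, because each starts from a limit and not from a number: the limit of > 200000 nM in this assay, at which 2 of the 4 values shown sit.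

On these data alone, whether hydrogen in place of fluoro, ortho to a large group, changes the number at all therefore stays open, as does how chloro, trifluoromethyl or an amine on an aromatic carbon of this ring would compare with bromo. The compounds shown also leave open how the number would respond if a methyl ester took the place of the carboxylic acid of the shared core.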